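Compound 1 to compound 3: pentyl chain to phenyl

This account rests on a few compounds, and the source may have more. Where it says the series, first, only, none or still open, it means among the compounds named here.

In a functional assay on MV4-11 cells (Homo sapiens) for antiproliferative activity, read by CCK-8 assay, with a stated time of 72 h (a higher number here means a weaker inhibitor, a lower number a stronger inhibitor), compound 1 (`CC(C)Oc1ccc(C(C)(C)O)cc1-c1cn(C)c(=O)c2[nH]c(C(=O)NCCCCCCC(=O)NO)cc12`) gives 160 nM and compound 2 (`Cc1cc(F)cc(C)c1Oc1ccc(C(C)(C)O)cc1-c1cn(C)c(=O)c2[nH]c(C(=O)NCCCCCCC(=O)NO)cc12`) gives 300 nM so the two values sit within the scatter of each other. Compound 3 (`CC(C)Oc1ccc(C(C)(C)O)cc1-c1cn(C)c(=O)c2[nH]c(C(=O)NCc3ccc(C(=O)NO)cc3)cc12`) carries 4-(hydroxycarbamoyl)phenyl in place of 5-(hydroxycarbamoyl)pentyl on a saturated chain carbon bound to an amide-type nitrogen. For the measured compounds named here, the only measured step (a 1.9-fold higher number from compound 1 to compound 2 (0.27 log units; within the scatter)) replaces isopropyl on an oxygen and leaves this chain untouched, so no measurement bears directly on the change. The expected step in this assay is (a 1.3-fold higher number from compound 1 to compound 3 (0.10 log units; within the scatter)), with no shift beyond the scatter expected in either direction. Compound 3 is estimated at 200 nM with a wide expected range from 60 nM to 650 nM for now.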

Compound 3, half-maximal inhibitory concentration: 350 nM
Estimate against measurement, compound 3: 1.8-fold (0.24 log units) below; the range from low to high includes it.
By their numbers in this assay, from the lowest: compounds 1, 2 and 3 (each within the scatter of the next, the first and the last beyond it).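

The chain on the amide-type nitrogen is sensitive to change: this assay records a 2.2-fold higher number from compound 1 to compound 3 (0.34 log units; beyond the scatter) on going from 5-(hydroxycarbamoyl)pentyl to 4-(hydroxycarbamoyl)phenyl, whereas the earlier change on the oxygen stayed within the scatter. The shift is modest, so the aromatic ring is tolerated here with only a limited loss. Nothing available explains this shift.

Open, from the compounds shown here alone, is whether a longer saturated chain would match or improve on compound 1. Also open, going by these compounds, is how a carboxylic acid in place of the hydroxycarbamoyl end would behave on either chain.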